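A few compounds are considered here, and "the series" means these few. Any claim that something is new, unique, unknown or untested is made for them only; others in the source may bear on it.

Working notes on the series. In a functional assay on HEK293 cells for antagonist activity at transient receptor potential cation channel subfamily V member 1 (Homo sapiens), read by calcium flux (a lower number here means a stronger inhibitor, a higher number a weaker inhibitor), compound 1 `O=C(Nc1ccc(I)cc1)c1ccc(OC(F)(F)F)cc1` gives 280 nM and compound 2 `O=C(Nc1ccc(C(F)(F)F)cc1)c1ccc(OC(F)(F)F)cc1` gives 220 nM; the two are linked by a 1.3-fold lower number from compound 1 to compound 2 (0.10 log units; within the scatter). Compound 3 `O=C(Nc1ccc(C2CCCCC2)cc1)c1ccc(OC(F)(F)F)cc1` is known in this assay only as a limit, > 10000 nM. So compound 3 stands at the weak end of the set, at the limit of > 10000 nM in this assay, at which 1 of the 3 values shown sits, with no number of its own.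

Compound 4 `O=C(Nc1ccc(-c2ccccc2)cc1)c1ccc(OC(F)(F)F)cc1` carries the change (phenyl in place of cyclohexyl on an aromatic carbon). Among the measured compounds shown here, no measured step compares phenyl with cyclohexyl. The steps that touch the cyclohexyl position are an at least 35-fold higher number from compound 1 to compound 3 (1.55 log units; beyond the scatter) and an at least 45-fold higher number from compound 2 to compound 3 (1.65 log units; beyond the scatter), both large and both toward weaker inhibition when cyclohexyl enters in place of a small group. Whether a phenyl in the same place behaves like the cyclohexyl or like the smaller groups cannot be read from these three compounds, and the limit on compound 3 leaves the size of the step open in either direction.

The estimate for compound 4 in this assay is therefore broad: the step from compound 3 to compound 4 is expected to be an at least 3.3-fold lower number from compound 3 to compound 4 (0.52 log units; beyond the scatter). Compound 4 is expected near 3000 nM, within roughly 400 nM to 20000 nM.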

Compound 4, half-maximal inhibitory concentration: > 10000 nM
Compound 4 was reported as a limit (the forecaster's own chance of this, stated with the estimate: 40%); middle value at least 3.3-fold (0.52 log units) away from the limit.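

In this assay, phenyl in place of the smaller groups gives an at least 45-fold higher number from compound 2 to compound 4 (1.65 log units; beyond the scatter) and an at least 35-fold higher number from compound 1 to compound 4 (1.55 log units; beyond the scatter), both large and both toward weaker inhibition. Among the compounds shown, a six-membered ring of carbon at this position, aromatic or not, loses the readable inhibition that iodo and trifluoromethyl keep. Compound 3 and compound 4 are both known only as a limit, not as a number: the limit of > 10000 nM in this assay, at which 2 of the 4 values shown sit.

Going by these compounds, the step between compound 3 and compound 4 cannot be read, so the order of phenyl and cyclohexyl remains unknown. Also open, on these data alone, is where between these smaller groups and the rings the loss sets in, which an ethyl or a tert-butyl at this position could begin to show, and whether an amine or a carboxylic acid there would keep inhibition.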